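Toward compound 3: a new aryl ether on the quinoline core

This account rests on a few compounds, and the source may have more. Where it says the series, first, only, none or still open, it means among the compounds named here.

Compound 2 `COc1cccc(CNCCCNc2ccnc3cc(-c4ccc(C(F)(F)F)cc4)ccc23)c1O` gives 2210 nM in an ADME assay on HepG2 cells (Homo sapiens) for cytotoxicity, read by luminescence, CellTiter-Glo and ATP content, with a stated time of 72 h (a lower number here means that less compound is needed, a higher number that more compound is needed for the effect), and stands highest of the two measured values; the nearest is compound 1 `COc1ccc(F)cc1CNCCCNc1ccnc2cc(Cc3cc(C)cc(C)c3)ccc12`, which in this assay gives 940 nM, a step beyond the usual scatter. Compound 3 `COc1ccccc1Oc1ccc2c(NCCCNCc3cccc(OC)c3O)ccnc2c1` differs from compound 2 in one place: 2-methoxyphenoxy in place of 4-(trifluoromethyl)phenyl on an aromatic carbon. Among the compounds with values here, with no measured pair showing this change, the step of a 1.2-fold higher number from compound 2 to compound 3 (0.07 log units; within the scatter) is expected to be small, within the scatter, or only slightly upward. On that basis compound 3 is estimated at 2600 nM, with a range from 1200 nM to 5600 nM.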

Compound 3, half-maximal effective concentration: 11200 nM
Compound 3: the middle estimate sits 4.3-fold (0.63 log units) below what was measured; measured number above the stated range.
By their numbers in this assay, from the lowest: compound 1; then compound 2; then compound 3.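

This position on the shared core responds to the group it carries: in this assay, 2-methoxyphenoxy in place of 4-(trifluoromethyl)phenyl gives a 5.1-fold higher number from compound 2 to compound 3 (0.70 log units; beyond the scatter), so more compound is needed for the effect. Both groups carry one six-membered aromatic ring, but only the entering group has hydrogen-bond acceptors. No measurement shown accounts for this step. A single pair leaves open whether the step follows the methoxy group, the ether oxygen or the loss of trifluoromethyl. From the compounds shown here alone, how a plain phenoxy group or a morpholine would read at this position also remains open.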